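The source may hold more compounds than are shown below. What is called first, only, known or untested is meant among the compounds shown, and "the series" means these compounds.

Compound 1 `Cc1ccc(-c2nn(-c3ccc(Cl)cc3)cc2C(CC(=O)c2ccc(Cl)cc2)C(=O)c2ccc(F)cc2)cc1` and compound 2 `COc1ccc(C(=O)C(CC(=O)c2ccc(Cl)cc2)c2cn(-c3ccc(Cl)cc3)nc2-c2ccc(C)cc2)cc1` share one core, while compound 3 `COc1ccc(-c2nn(-c3ccc(S(N)(=O)=O)cc3)cc2-c2cc(-c3ccc(Cl)cc3)[nH]c2-c2ccc(F)cc2)cc1` rests on another; the difference between the two cores is not broken down here. In a functional assay on the whole organism (strain Wistar albino) for inhibition, with Rattus norvegicus as the target, read by paw edema, with stated times of 1 h and 2 h, at a dose of 0.32 mmol/kg by the intraperitoneal route (on this read-out lower numbers stand for less inhibition and higher numbers for more inhibition at the one dose given (going by the name of the read-out)), compound 1 gives 25.9%, and compound 2 gives 16.1%. The change from compound 1 to compound 2 is methoxy in place of fluoro on an aromatic carbon, and it made a number 9.8 percentage points lower from compound 1 to compound 2 (within the scatter). In this assay compound 3 gives 55.7%, the highest of the three numbers. Compound 4 `COc1ccc(-c2nn(-c3ccc(S(N)(=O)=O)cc3)cc2-c2cc(-c3ccc(Cl)cc3)[nH]c2-c2ccc(OC)cc2)cc1` has not yet been measured; it differs from compound 3 by methoxy in place of fluoro on an aromatic carbon, the same change as before, again on an aromatic carbon para to a large group. Because the earlier step of a number 9.8 percentage points lower from compound 1 to compound 2 (within the scatter) stayed within the scatter, compound 4 is expected to shift only a little, by a number 5.7 percentage points lower from compound 3 to compound 4 (within the scatter). Compound 4 is therefore estimated at 50%, between 35% and 65%.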

Compound 4, a percentage reported as inhibition, in the whole organism at one dose (the size of the read-out at that dose, not a potency): 48.2%
Beside the measured number, compound 4's estimate is 1.8 percentage points above it; low and high end bracket the measured number.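

In this assay methoxy in place of fluoro gave a number 7.5 percentage points lower from compound 3 to compound 4 (within the scatter) and so matched the step on the other core: the same change on two cores in this assay, a number 9.8 percentage points lower (within the scatter) from compound 1 to compound 2 and a number 7.5 percentage points lower (within the scatter) from compound 3 to compound 4, 2.3 percentage points apart, within the scatter of two such steps.
On these two cores, then, the change from 4-fluorophenyl to 4-methoxyphenyl carries over with no step beyond the scatter. Among these compounds, this rests on only two pairs, and since each step lies within the scatter, it does not show that methoxy truly lowers the number, nor that the match would hold on a further core.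

The compounds shown leave open how an amine, a carboxylic acid or a longer chain such as butoxy would read in the place of the fluoro. They also leave open whether the same change elsewhere on these cores would behave alike.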